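Acetyl to Vinylcarbonyl: Expecting the Number for Compound 4

A few compounds are considered here, and "the series" means these few. Any claim that something is new, unique, unknown or untested is made for them only; others in the source may bear on it.

Of the compounds shown here, three sharing one core have been measured in a functional assay on MGC-803 cells (Homo sapiens) for inhibition, read by MTT assay, with a stated time of 48 h; on this read-out higher numbers stand for weaker inhibition and lower numbers for stronger inhibition. Compound 1 `COc1ccc(CNc2cc(OC)c(OC)c(OC)c2)cc1Br` gives 29400 nM, compound 3 `C/C=C/C(=O)N(Cc1ccc(OC)c([N+](=O)[O-])c1)c1cc(OC)c(OC)c(OC)c1` gives 590 nM, and compound 2 `COc1ccc(CN(C(C)=O)c2cc(OC)c(OC)c(OC)c2)cc1O` gives 79 nM. Compound 2 therefore holds the lowest number of the three; compound 3 sits closest and compound 1 furthest, and both gaps lie beyond the usual scatter. Compound 4 `C=CC(=O)N(Cc1ccc(OC)c(O)c1)c1cc(OC)c(OC)c(OC)c1` has not yet been measured in this assay. It differs from compound 2 in one place: vinyl in place of methyl on a carbonyl carbon. Going by the values given here, no measured pair shows this acetyl to vinylcarbonyl change on its own, so the step has to be guessed. The step of a 1.5-fold higher number from compound 2 to compound 4 (0.18 log units; within the scatter) is expected to be small, toward a higher number, within or barely beyond the scatter. Compound 4 is estimated at 120 nM, in the range 40 nM to 400 nM.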

Compound 4, half-maximal inhibitory concentration: 62 nM
Beside the measured number, compound 4's estimate is 1.9-fold (0.29 log units) above it; low and high end bracket the measured number.
By their numbers in this assay, from the lowest: compounds 4 and 2 (each within the scatter of the next); then compound 3; then compound 1.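

In this assay, going by these compounds alone, replacing methyl with vinyl on a carbonyl carbon gives a 1.3-fold lower number from compound 2 to compound 4 (0.11 log units; within the scatter), the first direct reading of a change at this position. The position therefore takes one more carbon and a double bond outside aromatic rings with no step beyond the scatter. Nothing available explains why the two groups read alike. On these data alone, it remains open how far this tolerance extends: a longer chain such as butyl, or an amine on the carbonyl carbon, could give a very different number.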